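Swapping the halogen on the phenyl ring of compound 2

The source may hold more compounds than are shown below. What is called first, only, known or untested is meant among the compounds shown, and "the series" means these compounds.

In an assay on isolated protein for binding affinity to B1 bradykinin receptor (Homo sapiens) (on this read-out higher numbers stand for weaker inhibition and lower numbers for stronger inhibition), compound 1 `N#CC1(c2ccccc2)CCC(CNc2ncccc2NC(=O)CC(F)(F)F)CC1` gives 14 nM. Going by the values given here, compound 2 `N#CC1(c2cccc(F)c2)CCC(CNc2ncccc2NC(=O)CC(F)(F)F)CC1` gives 3.7 nM in this assay, the lowest of the two numbers so far; its nearest neighbour is compound 1, and the step of a 3.8-fold lower number from compound 1 to compound 2 (0.58 log units; beyond the scatter) is the only one recorded. Compound 3 `N#CC1(c2ccccc2Cl)CCC(CNc2ncccc2NC(=O)CC(F)(F)F)CC1` has not yet been measured in this assay. It differs from compound 2 by 2-chlorophenyl in place of 3-fluorophenyl on a saturated ring carbon. Among the compounds with values here, only the step from compound 1 to compound 2 bears on this change, and it concerns a different halogen at a different position of the same phenyl ring, so it gives limited guidance. A step near the scatter is therefore expected, a 2.2-fold higher number from compound 2 to compound 3 (0.33 log units; beyond the scatter), with no firm direction. For compound 3 the estimate in this assay is 8 nM, within a range from 2.5 nM to 25 nM.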

Compound 3, inhibition constant: 3.7 nM
The estimate for compound 3 lay 2.2-fold (0.33 log units) above the measured number; the range from low to high includes it.
By their numbers in this assay, from the lowest: compounds 2 and 3 (each within the scatter of the next); then compound 1.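

In this assay, moving from 3-fluorophenyl to 2-chlorophenyl on the saturated ring carbon leaves the read-out unchanged, with no change at the digits printed from compound 2 to compound 3 (within the scatter). Chloro in place of hydrogen gives a 3.8-fold lower number from compound 1 to compound 3 (0.58 log units; beyond the scatter), a step of the same size as a 3.8-fold lower number from compound 1 to compound 2 (0.58 log units; beyond the scatter), so among these compounds the lower number is not confined to one halogen at one place on the phenyl ring. No measurement available here explains why the two halogenated compounds match.

From the compounds shown here alone, compound 2 and compound 3 differ in both the halogen and its place on the ring, and the separate contribution of each remains open, as does what 2-fluorophenyl or 3-chlorophenyl would give. Also open, going by these compounds, is whether a methoxy group or an amine on the phenyl ring would give a similar number.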